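This account rests on a few compounds, and the source may have more. Where it says the series, first, only, none or still open, it means among the compounds named here.

Series notes. Of the compounds shown here, three sharing one core have been measured in a functional assay for inhibition, with Homo sapiens as the target; on this read-out lower numbers stand for stronger inhibition and higher numbers for weaker inhibition. Compound 3 `COc1cccc(Nc2nccc(-c3ccc(C)o3)n2)c1` gives 1500 nM. Compound 1 `COc1cccc(Nc2nccc(-c3cc(C)oc3C)n2)c1` gives 5800 nM. Compound 2 `CCN(CC)c1ccc(Nc2nccc(-c3ccc(C)o3)n2)cc1` gives 28000 nM, the highest of the three numbers. Between compound 3 and compound 1 the cores differ in one place (2,5-dimethylfuran-3-yl in place of 5-methylfuran-2-yl on an aromatic carbon), and the step of a 3.9-fold higher number from compound 3 to compound 1 (0.59 log units; beyond the scatter) is beyond the scatter. Between compound 2 and compound 3 the difference of the cores is not broken down here; the two values alone show the gap.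

Compound 4 `CCN(CC)c1ccc(Nc2nccc(-c3cc(C)oc3C)n2)cc1` is not yet measured. It differs from compound 2 in one place (2,5-dimethylfuran-3-yl in place of 5-methylfuran-2-yl on an aromatic carbon). The surroundings are not described word for word the same: around compound 1 the change sits meta to a group of 9 heavy atoms, around compound 4 meta to a large group, so this is the same kind of change rather than the same one. Because of a 3.9-fold higher number from compound 3 to compound 1 (0.59 log units; beyond the scatter) a step of similar direction and size is expected here, a 3.2-fold higher number from compound 2 to compound 4 (0.51 log units; beyond the scatter), which rests on that single earlier pair only. Compound 4 is accordingly estimated at 90000 nM in this assay, with 30000 nM to 300000 nM as the expected range.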

Compound 4, half-maximal inhibitory concentration: > 24000 nM
Compound 4: a limit, no number; the forecaster's own chance of this, stated with the estimate: 30%; the middle value is on the limit's open side.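

In this assay compound 4 gives > 24000 nM, which is a limit and not a number. No step from compound 2 to compound 4 can be read, since the result stands only as a limit: the limit of > 24000 nM in this assay, at which 1 of the 4 values shown sits.

From the compounds shown here alone, whether 2,5-dimethylfuran-3-yl in place of 5-methylfuran-2-yl raises the number on the core of compound 2, as it does from compound 3 to compound 1, and by how much, stays open.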